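Oxazolyl in place of allyl on the amide nitrogen

The source may hold more compounds than are shown below. What is called first, only, known or untested is meant among the compounds shown, and "the series" means these compounds.

Three compounds of this series have numbers in an assay on HEK293 cells for agonist activity at transient receptor potential cation channel subfamily M member 8 (Homo sapiens), read by fluorescence and calcium flux, with a stated time of 15 min; a higher number here means that more compound is needed for the effect, a lower number that less compound is needed. Compound 1 `C=CCN(Cc1cccs1)C(=O)COc1ccc(C)cc1` gives 20 nM, the lowest of the three. Compound 2 `CCN(Cc1cccs1)C(=O)CCc1ccc(C)cc1` gives 93 nM, and compound 3 `CCN(Cc1cccs1)C(=O)c1cc2cc(C)ccc2s1` gives 1600 nM. Compound 1 thus stands at the favourable end: its gap to compound 2 is beyond the usual scatter, and its gap to compound 3 is far beyond it. Within the data shown here, no two of these three compounds differ in a single place, so no measured single step exists in the set.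

Compound 4 `Cc1ccc(OCC(=O)N(Cc2cccs2)c2ncco2)cc1` is the next compound to be measured in this assay. It differs from compound 1 at one position: 1,3-oxazol-2-yl in place of allyl on an amide-type nitrogen. Among the measured compounds shown here, nothing measured so far tests a ring on this nitrogen, only chains. The step of a 5.0-fold higher number from compound 1 to compound 4 (0.70 log units; beyond the scatter) is expected to be a moderate rise, beyond the scatter, toward the weaker part of the range seen so far. Compound 4 is estimated at 100 nM, with a range from 20 nM to 600 nM.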

Compound 4, half-maximal effective concentration: 0.3 nM
Beside the measured number, compound 4's estimate is 330-fold (2.52 log units) above it; measured number below the stated range.
By their numbers in this assay, from the lowest: compound 4; then compound 1; then compound 2; then compound 3.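

The amide-type nitrogen accepts a ring as well as a chain: in this assay replacing allyl with 1,3-oxazol-2-yl gives a 67-fold lower number from compound 1 to compound 4 (1.82 log units; beyond the scatter) and puts compound 4 lowest of the four compounds. Among these compounds, the position is therefore far more responsive to its substituent than the earlier compounds could reveal, since none of them isolated a change at this nitrogen. The data at hand give no measured basis for explaining the size of this step.

Open, as far as these compounds go, is whether the gain depends on the ring's nitrogen and oxygen or on the aromatic ring alone, a question that a phenyl or a 1,3-thiazol-2-yl group on the same nitrogen would address. Also open, from the compounds shown here alone, is whether 1,3-oxazol-2-yl would have a similar effect on the amide nitrogen of compound 2 or compound 3.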